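The source may hold more compounds than are shown below. What is called first, only, known or untested is meant among the compounds shown, and "the series" means these compounds.

Compound 1 `CC(C)(C)OC(=O)N1CCN(c2ccc(OCc3ccc(S(C)(=O)=O)cc3)cn2)CC1` — 112%
Compound 2 `C[C@@H]1CN(C(=O)OC(C)(C)C)CCN1c1ncc(OCC2CCN(S(C)(=O)=O)CC2)cn1` — 67%

In a functional assay on isolated protein with Glucose-dependent insulinotropic receptor (Mus musculus) as the target, read by HTRF and cAMP accumulation, with a stated time of 45 min (on this read-out higher numbers stand for larger maximal responses and lower numbers for smaller maximal responses), compound 1 gives 112%, whereas compound 2 gives 67%. For the measured compounds named here, compound 2 thus stands lowest of the two numbers; its only neighbour, compound 1, lies higher by a gap that exceeds the usual scatter. Going by the values given here, no pair of measured compounds differs in a single place, so the two values show only that compound 1 reaches a larger maximal response than compound 2.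

Compound 3 `C[C@@H]1CN(C(=O)OC(C)(C)C)CCN1c1ncc(OCc2ccc(-n3cnnn3)cc2)cn1` is the unmeasured compound. It differs from compound 2 in one place: 4-(1H-tetrazol-1-yl)phenyl in place of 1-(methylsulfonyl)piperidin-4-yl on a saturated chain carbon bound to an oxygen on an aromatic ring. With an aromatic carbocycle now joined to the saturated chain carbon bound to the ring oxygen, compound 3 resembles compound 1 more closely than compound 2 does. The direction of the step from compound 2 to compound 1 suggests an expected rise for compound 3 in this assay, beyond the scatter, as the estimated step of a number 23 percentage points higher from compound 2 to compound 3 (beyond the scatter). Compound 3 is therefore estimated at 90%, with a likely range from 65% to 115%.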

Compound 3, intrinsic activity: the largest response reached, in percent of the reference agonist's: 115%
Estimate against measurement, compound 3: 25 percentage points below; the measured number falls inside the stated range.
By their numbers in this assay, from the lowest: compound 2; then compounds 1 and 3 (each within the scatter of the next).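

In this assay, putting 4-(1H-tetrazol-1-yl)phenyl in place of 1-(methylsulfonyl)piperidin-4-yl on a saturated chain carbon bound to an oxygen on an aromatic ring gives a number 48 percentage points higher from compound 2 to compound 3 (beyond the scatter). For the compounds shown here, this is the first comparison here in which only one place changes, so it shows that the maximal response depends on the group at this position, something the two earlier compounds, which differ in more than one place, could not show. The swap exchanges a non-aromatic ring bearing a sulfonyl group for two linked aromatic rings, and nothing available accounts for the size of the step.

Going by these compounds, what an unsubstituted phenyl or a 4-carboxyphenyl would give at this position remains open, so the step cannot yet be divided between the phenyl ring and the tetrazole. Also open, on these data alone, are how the same swap would behave on the core of compound 1 and whether potency would follow the maximal response.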